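From 4-bromobenzyl to 2-methylbenzyl on the shared core

The source may hold more compounds than are shown below. What is called first, only, known or untested is meant among the compounds shown, and "the series" means these compounds.

Compound 1 `C=CCOc1ccc2c(=O)c(-c3cc(OC)c(OC)cc3OC)coc2c1` gives 4750 nM
Compound 2 `COc1cc(OC)c(-c2coc3cc(OCc4ccc(F)cc4)ccc3c2=O)cc1OC` gives 1720 nM
Compound 3 `COc1cc(OC)c(-c2coc3cc(OCc4ccc(Br)cc4)ccc3c2=O)cc1OC` gives 1000 nM

These values come from a functional assay on A-375 cells (Homo sapiens) for antiproliferative activity, read by MTT assay, with a stated time of 24 h (on this read-out higher numbers stand for weaker inhibition and lower numbers for stronger inhibition), and they put compound 3 together with compound 2 at the low end of the three numbers. Bromo in place of fluoro on an aromatic carbon gave a 1.7-fold lower number from compound 2 to compound 3 (0.24 log units; within the scatter) and so does not separate the pair. Compound 1 stands apart from both: 4-fluorophenyl in place of vinyl gave a 2.8-fold lower number from compound 1 to compound 2 (0.44 log units; beyond the scatter) and 4-bromophenyl in place of vinyl gave a 4.8-fold lower number from compound 1 to compound 3 (0.68 log units; beyond the scatter) as modest steps.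

Compound 4 `COc1cc(OC)c(-c2coc3cc(OCc4ccccc4C)ccc3c2=O)cc1OC` is still unmeasured and carries 2-methylphenyl in place of 4-bromophenyl on a saturated chain carbon bound to an oxygen on an aromatic ring, a difference counted as 2-methylphenyl in place of 4-bromophenyl on a saturated chain carbon bound to an oxygen on an aromatic ring on otherwise identical structures. Among the measured compounds shown here, no measured compound carries a methyl group on this ring, so the evidence is indirect. The nearest guide is a 1.7-fold lower number from compound 2 to compound 3 (0.24 log units; within the scatter) for a change on the phenyl ring itself, and this is smaller than the steps away from vinyl. No step beyond the scatter is therefore expected, and the estimated step is a 1.5-fold higher number from compound 3 to compound 4 (0.18 log units; within the scatter) with a slight upward lean. In this assay compound 4 is estimated at 1500 nM with an expected range from 650 nM to 3500 nM for the coming measurement.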

Compound 4, half-maximal inhibitory concentration: 1360 nM
Compound 4: middle estimate off by 1.1-fold (0.04 log units), on the high side; the measured number falls inside the stated range.
By their numbers in this assay, from the lowest: compounds 3, 4 and 2 (each within the scatter of the next); then compound 1.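

With 2-methylphenyl on the saturated chain carbon bound to an oxygen on an aromatic ring, the set gains a phenyl group that carries methyl rather than a halogen, yet this assay does not separate it from either halogen-bearing group: the change gives a 1.4-fold higher number from compound 3 to compound 4 (0.13 log units; within the scatter) and a 1.3-fold lower number from compound 2 to compound 4 (0.10 log units; within the scatter). A halogen on the phenyl ring is therefore not required to reach the level shared by compound 2 and compound 3, while a 3.5-fold lower number from compound 1 to compound 4 (0.54 log units; beyond the scatter) shows that the separation from the vinyl group also holds for this non-halogen group, so all three phenyl-bearing compounds stand apart from compound 1. Nothing measured here gives a reason why these three groups fall together.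

The compounds shown tie the kind of substituent to its place on the ring, so 4-methylphenyl and 2-bromophenyl would be needed to tell the two apart. They also leave open how a plain phenyl, a phenyl ring carrying an amine or a carboxylic acid, or a longer chain at this position would behave in this assay.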